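The source may hold more compounds than are shown below. What is called first, only, known or untested is meant among the compounds shown, and "the series" means these compounds.

Measured so far in an ADME assay on cells (Hepatocyte, Homo sapiens) for pharmacokinetics, read by LC-MS, with a stated time of 90 min, tested at 1 uM; on this read-out higher numbers stand for fast clearance and lower numbers for slow clearance:
compound 1, `O=C(CCCCCNc1c(NCc2ccccc2)c(=O)c1=O)NO`: < 4.8 uL/min, a limit of the assay
compound 2, `C[C@@H](Nc1c(NCCCCCC(=O)NO)c(=O)c1=O)c1ccccc1`: < 5 uL/min, a limit of the assay
compound 3, `CCC(CCCCC(=O)NO)Nc1c(Nc2ccc(C(F)(F)F)cc2)c(=O)c1=O`: 25 uL/min

The value of compound 1 is a limit and not a number, as the limit of < 4.8 uL/min in this assay, at which 1 of the 3 values shown sits, states. The value of compound 2 is likewise a limit, as the limit of < 5 uL/min in this assay, at which 1 of the 3 values shown sits, states. Among the measured compounds shown here, compound 3 gives the only number in this assay. The change from compound 1 to compound 2 is methyl in place of hydrogen on a saturated chain carbon bound to an aromatic carbon and a nitrogen on an aromatic ring; the resulting step, a step that the two limits leave unreadable from compound 1 to compound 2, is left unreadable by the two limits. How the core of compound 3 differs from that of compound 1 is not broken down here.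

Compound 4, `CC(C)C(CCCCC(=O)NO)Nc1c(Nc2ccc(C(F)(F)F)cc2)c(=O)c1=O`, is not yet measured in this assay. It differs from compound 3 by methyl in place of hydrogen on a saturated chain carbon bound to two saturated chain carbons, the same kind of change as from compound 1 to compound 2, but at a different place: there the carbon is bound to an aromatic carbon and a nitrogen on an aromatic ring, here to two saturated chain carbons. With the earlier step unreadable, the expectation rests on compound 3 and its value of 25 uL/min, with one methyl added; the step from compound 3 to compound 4 is expected to be a 1.2-fold higher number from compound 3 to compound 4 (0.08 log units; within the scatter). Compound 4 is estimated at 30 uL/min, between 12 uL/min and 70 uL/min.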

Compound 4, intrinsic clearance in a liver preparation (reported as CLH), per the amount of preparation that the assay uses: 27 uL/min
Compound 4: middle estimate off by 1.1-fold (0.05 log units), on the high side, within the range that was stated.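

In this assay, methyl in place of hydrogen on a saturated chain carbon bound to two saturated chain carbons gives a 1.1-fold higher number from compound 3 to compound 4 (0.03 log units; within the scatter), so on the core of compound 3 this change leaves the read-out within the scatter. The same kind of change on the core of compound 1, on a saturated chain carbon bound to an aromatic carbon and a nitrogen on an aromatic ring, cannot be read, with a limit of the assay at both ends, so the compounds shown give neither agreement nor disagreement between the two cores and no basis for carrying the step from one to the other. Nothing measured here gives a cause for the size of the new step.

Open, as far as these compounds go, is whether one further methyl at the same place, reading isopropyl to tert-butyl, would also stay within the scatter in this assay. Also open, from the compounds shown here alone, is what an amine or a longer chain in place of the ethyl or isopropyl would give on this core.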